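Replacing Ethylsulfonyl with (Trifluoromethyl)carbonyl on the Nitrogen

This account rests on a few compounds, and the source may have more. Where it says the series, first, only, none or still open, it means among the compounds named here.

Measured so far in an assay on isolated protein for binding affinity to Alpha-1A adrenergic receptor (Rattus norvegicus), read by radioligand binding; a higher number here means a weaker inhibitor, a lower number a stronger inhibitor:
compound 1, `CCS(=O)(=O)Nc1cccc2c1CCCC2c1c[nH]cn1`: 46.8 nM
compound 2, `CCS(=O)(=O)Nc1cccc2c1CCCC2(O)c1c[nH]cn1`: < 10000 nM (a limit)
compound 3, `CCS(=O)(=O)Nc1cccc2c1CCCC2CNC`: 1380 nM

Compound 1 gives the lowest of the two numbers shown. Its nearest measured neighbour is compound 3, and the step of a 29-fold higher number from compound 1 to compound 3 (1.47 log units; beyond the scatter), (methylamino)methyl in place of 1H-imidazol-4-yl on a saturated ring carbon, is large. For compound 2 only a limit is reported in this assay. The step that the limit leaves unreadable from compound 1 to compound 2, hydroxy in place of hydrogen on a saturated ring carbon, can therefore not be sized (the limit of < 10000 nM in this assay, at which 1 of the 3 values shown sits).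

Compound 4 `O=C(Nc1cccc2c1CCCC2c1c[nH]cn1)C(F)(F)F` has not yet been measured. It differs from compound 1 by (trifluoromethyl)carbonyl in place of ethylsulfonyl on a nitrogen on an aromatic ring. Both measured steps alter the substituent on a saturated ring carbon, whereas this change sits on a nitrogen on an aromatic ring, so neither bears directly on it. With nothing showing how that position responds, the expectation is a change of modest size in no certain direction. Compound 4 is estimated at 100 nM, within 20 nM to 600 nM. That estimate corresponds to an expected 2.1-fold higher number from compound 1 to compound 4 (0.33 log units; beyond the scatter) in this assay.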

Compound 4, inhibition constant: 166 nM
Compound 4: the middle estimate sits 1.7-fold (0.22 log units) below what was measured; the range from low to high includes it.
By their numbers in this assay, from the lowest: compound 1; then compound 4; then compound 3.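

Among the compounds shown here, the first reading at this position in this assay is a 3.5-fold higher number from compound 1 to compound 4 (0.55 log units; beyond the scatter), so the substituent on the nitrogen on an aromatic ring does register in this assay, though only modestly. For the compounds shown here, the change on the saturated ring carbon that swapped 1H-imidazol-4-yl for (methylamino)methyl gave a large step, a 29-fold higher number from compound 1 to compound 3 (1.47 log units; beyond the scatter), while here a group with no sulfur and one hydrogen-bond acceptor fewer still leaves a number of the same modest order as compound 1, so ethylsulfonyl is not the only group on this nitrogen that gives a readable value. Nothing given here accounts for the size or direction of this step.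

With one replacement at this nitrogen, the loss of the sulfonyl and the arrival of the trifluoromethyl change together, and the compounds shown cannot separate what each contributes. An acetyl or a methylsulfonyl group on the same nitrogen would pull these apart, and a free amine there would show what the position gives with no acyl or sulfonyl group at all.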